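Series notes: sulfamoyl in place of hydrogen on compound 2

The compounds below may be only part of what the source reports. "The series", "measured", "known", "first", "only" and "open" are said of these compounds alone.

Within the data shown here, compound 2 `N#CC1CN1C(=O)Nc1ccccc1` gives 5300 nM in a functional assay on RPMI-8226 cells (Homo sapiens) for inhibition (a higher number here means a weaker inhibitor, a lower number a stronger inhibitor), and sits within the scatter of the only other number, that of compound 1 `CCOC(=O)c1ccc(NC(=O)N2CC2C#N)cc1`, which gives 3000 nM in this assay; the step of a 1.8-fold higher number from compound 1 to compound 2 (0.25 log units; within the scatter) is within the scatter. Compound 3 `N#CC1CN1C(=O)Nc1ccc(S(N)(=O)=O)cc1` differs from compound 2 by sulfamoyl in place of hydrogen on an aromatic carbon. Among the measured compounds shown here, the one measured step at this place, a 1.8-fold higher number from compound 1 to compound 2 (0.25 log units; within the scatter), was small, so no step beyond the scatter is expected in this assay, leaning if anything toward a lower number. For compound 3 the estimate is 3500 nM, range 1200 nM to 10000 nM. The expected step is a 1.5-fold lower number from compound 2 to compound 3 (0.18 log units; within the scatter).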

Compound 3, half-maximal inhibitory concentration: > 38000 nM
Compound 3 was reported as a limit; the forecaster's own chance of this, stated with the estimate: 10%; at least 10-fold (1.03 log units) between middle value and limit.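

Compound 3 is reported as a limit of the assay, not as a number: the limit of > 38000 nM in this assay, at which 1 of the 3 values shown sits. The earlier pair showed no step beyond the scatter at this aromatic carbon, whereas sulfamoyl gives an at least 7.1-fold higher number from compound 2 to compound 3 (0.85 log units; beyond the scatter) in this assay. Against the ester, the change gives an at least 12-fold higher number from compound 1 to compound 3 (1.10 log units; beyond the scatter) and so shows that the group at this place can matter.

Open, as far as these compounds go, is whether a methylsulfonyl group, which keeps the sulfur but lacks the nitrogen, behaves like sulfamoyl. Also open, from the compounds shown here alone, is where an amine or a carboxylic acid would fall at this carbon.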